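A Benzylamine in Place of Pyrrolidine on the Shared Core

The compounds below may be only part of what the source reports. "The series", "measured", "known", "first", "only" and "open" are said of these compounds alone.

Three compounds have been measured in a functional assay on L02 cells (Homo sapiens) for inhibition, read by Griess assay, with stated times of 1 h and 24 h; a lower number here means a stronger inhibitor, a higher number a weaker inhibitor:

compound 1, `CCCc1nn(C)c2c(NC(C)C)nc(/C=C/c3ccc[n+]([O-])c3)nc12`, gives 324000 nM.
compound 2, `COc1cc(/C=C/c2nccc(NC(C)C)n2)cc(OC)c1OC`, gives < 40000 nM.
compound 3, `COc1cc(/C=C/c2nc(N3CCCC3)c3sccc3n2)cc(OC)c1OC`, gives 681000 nM.

The figure given for compound 2 is a limit of this assay rather than a number (the limit of < 40000 nM in this assay, at which 1 of the 3 values shown sits). Of the two numbers, compound 3 stands highest; its nearest neighbour is compound 1, which sits at a lower number, and the gap between the two lies beyond the usual scatter of this assay.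

Compound 4, `COc1cc(/C=C/c2nc(NCc3ccccc3Cl)c3sccc3n2)cc(OC)c1OC`, differs from compound 3 in one place: (2-chlorobenzyl)amino in place of pyrrolidin-1-yl on an aromatic carbon. For the measured compounds named here, no pair of measured compounds differs in just this way, so the size of the step has to be judged without a measured precedent. Compound 2 carries a secondary amine on its own core and reaches the limit, while compound 1, also with a secondary amine but on a different core, gives a high number; these two values set wide bounds rather than a direction. A moderate move toward a lower number, that is toward stronger inhibition, is expected in this assay for compound 4, with the outcome uncertain either way. Compound 4 is estimated at 300000 nM, within a range from 60000 nM to 1500000 nM. The expected step of a 2.3-fold lower number from compound 3 to compound 4 (0.36 log units; beyond the scatter) reflects that estimate.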

Compound 4, half-maximal inhibitory concentration: > 1000000 nM
Compound 4: no number, only a limit; the forecaster's own chance of this, stated with the estimate: 15%; at least 3.3-fold (0.52 log units) between middle value and limit.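

In this assay, for the compounds shown here, putting (2-chlorobenzyl)amino in place of pyrrolidin-1-yl on this aromatic carbon of the shared core gives an at least 1.4-fold higher number from compound 3 to compound 4 (0.16 log units; that floor lies within the scatter), the first direct reading of a change at this position. The exchange adds a six-membered aromatic ring of carbon only and a hydrogen-bond donor, yet it brings no move toward a lower number, so on this core neither addition yields stronger inhibition in this pair. On these data alone, compound 4 has no number here, only a limit of the assay, so the size of the step stays unknown and the pair cannot be said to separate by more than the usual scatter: the limit of > 1000000 nM in this assay, at which 1 of the 4 values shown sits.

The compounds shown leave open which part of the new group governs the result, since the ring chlorine, the benzyl unit and the amine hydrogen all enter together. An unsubstituted benzylamino group or a morpholine ring on the same carbon would help to tell these apart, and a group that gave a number rather than a limit would fix how far this position can move the read-out.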